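Swapping the aniline substituent: halogens for an ethyl group

A few compounds are considered here, and "the series" means these few. Any claim that something is new, unique, unknown or untested is made for them only; others in the source may bear on it.

Measured compounds:
compound 1 `O=C(/C=C/c1cccnc1)NCCCCCCc1ccc(S(=O)(=O)Nc2ccccc2)cc1`, 14.4 nM in an assay on isolated protein for inhibition of Nicotinamide phosphoribosyltransferase (Homo sapiens), read by WST assay, with stated times of 60 min, 5 min and 30 min, in the presence of a further agent that is not named here; on this read-out lower numbers stand for stronger inhibition and higher numbers for weaker inhibition
compound 2 `O=C(/C=C/c1cccnc1)NCCCCCCc1cccc(S(=O)(=O)Nc2ccccc2)c1`, 10.5 nM in this assay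
compound 3 `CCc1ccc(NS(=O)(=O)c2cccc(CCCCCCNC(=O)/C=C/c3cccnc3)c2)cc1`, 31.5 nM in this assay

Compound 3 gives the highest number of the three, and its gaps to compound 1 and to compound 2 both lie beyond the scatter. For the measured compounds named here, the one step that touches the aniline ring is a 3.0-fold higher number from compound 2 to compound 3 (0.48 log units; beyond the scatter), a modest rise. Compound 4 `O=C(/C=C/c1cccnc1)NCCCCCCc1cccc(S(=O)(=O)Nc2ccc(F)c(Cl)c2)c1` carries 3-chloro-4-fluorophenyl in place of 4-ethylphenyl on a sulfonamide nitrogen. Going by the values given here, no measured step covers a halogenated aniline, so the expectation rests only on compound 3 and on the single prior step. For compound 4 the estimate is a 1.6-fold lower number from compound 3 to compound 4 (0.20 log units; within the scatter), a small move toward the unsubstituted compound 2 that may stay within the scatter. Compound 4 is therefore expected at 20 nM, within 8 nM to 50 nM.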

Compound 4, half-maximal inhibitory concentration: 9.7 nM
Estimate against measurement, compound 4: 2.1-fold (0.31 log units) above, and the stated range covers the measured number.
By their numbers in this assay, from the lowest: compounds 4, 2 and 1 (each within the scatter of the next); then compound 3.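

A substituted ring on the sulfonamide nitrogen need not cost anything: a 1.1-fold lower number from compound 2 to compound 4 (0.03 log units; within the scatter) leaves 3-chloro-4-fluorophenyl level with plain phenyl. With a 3.2-fold lower number from compound 3 to compound 4 (0.51 log units; beyond the scatter) in hand, the rise seen in compound 3 belongs to the 4-ethylphenyl group, not to substitution of this ring in general. Nothing available here explains why the ethyl and halogen versions differ. Still open, going by these compounds, is whether a methoxy group, an amine or a carboxylic acid on this ring would match the halogens or the ethyl group. Also open, on these data alone, is whether chlorine or fluorine alone would match the pair.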